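The compounds below may be only part of what the source reports. "The series", "measured", "known", "first", "only" and "open" are said of these compounds alone.

Compound 1 `CCc1ccccc1OS(=O)(=O)c1cccc(NC(=O)NCCCCl)c1` carries an ethyl group on its aromatic ring and, in a functional assay on M21 cells (Homo sapiens) for cytotoxicity, read by sulforhodamine B assay, with a stated time of 48 h (on this read-out lower numbers stand for stronger inhibition and higher numbers for weaker inhibition), compound 1 gives 24000 nM. Compound 2 `CCCc1ccccc1OS(=O)(=O)c1cccc(NC(=O)NCCCCl)c1` differs from it by methyl in place of hydrogen on a saturated chain carbon, two bonds along the chain from an aromatic carbon, and in this assay compound 2 gives 15000 nM, so that a 1.6-fold lower number from compound 1 to compound 2 (0.20 log units; within the scatter). Compound 3 `CCc1ccccc1NS(=O)(=O)c1cccc(NC(=O)NCCCCl)c1` has a different core from compound 1, and the difference between the two cores is not broken down here. In this assay compound 3 reaches only the limit > 200000 nM, which is not a number. That limit is the limit of > 200000 nM in this assay, at which 1 of the 3 values shown sits. Compound 4 `CCCc1ccccc1NS(=O)(=O)c1cccc(NC(=O)NCCCCl)c1` is still to be measured in this assay and differs from compound 3 by methyl in place of hydrogen on a saturated chain carbon, two bonds along the chain from an aromatic carbon, the same change that separates compound 1 from compound 2. Since that earlier step stayed within the scatter, the step is expected to be a number no higher from compound 3 to compound 4 (the limit leaves the size open), and this rests on a 1.6-fold lower number from compound 1 to compound 2 (0.20 log units; within the scatter). Because compound 3 sits at the limit of > 200000 nM in this assay, at which 1 of the 3 values shown sits, compound 4 is expected to sit there too. For compound 4 the estimated value in this assay is 200000 nM, within a range from 70000 nM to 600000 nM, most likely reported as a limit rather than a number.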

Compound 4, half-maximal inhibitory concentration: 23000 nM
Estimate against measurement, compound 4: 8.7-fold (0.94 log units) above, and the stated range ends above it.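

In this assay, going by these compounds, methyl in place of hydrogen on a saturated chain carbon, two bonds along the chain from an aromatic carbon, gives an at least 8.6-fold lower number from compound 3 to compound 4 (0.93 log units; beyond the scatter), so this change, ethyl to propyl, does not carry over unchanged from the core of compound 1 to the core of compound 3: the same change on two cores in this assay, a 1.6-fold lower number (0.20 log units; within the scatter) from compound 1 to compound 2 and an at least 8.6-fold lower number (0.93 log units; beyond the scatter) from compound 3 to compound 4, at least 5.4-fold (0.73 log units) apart, beyond the scatter of two such steps The true size of the new step stays open, since compound 3 stands at a limit and not at a number: the limit of > 200000 nM in this assay, at which 1 of the 4 values shown sits. With a single pair on each core, this shows that the result of the change differs between these two cores, but it does not show why, nor whether the same would hold for any other change.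

The compounds shown leave open whether a longer chain, such as butyl in place of propyl, would follow the same course on each core. They also leave open how a branched group such as isopropyl, or an amine at the end of the chain, would behave on either core.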